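Tert-butyl in place of trifluoromethoxy: expected step

The compounds below may be only part of what the source reports. "The series", "measured", "known", "first", "only" and "open" are said of these compounds alone.

The series keeps a shared core and varies one group on an aromatic carbon. In a functional assay on DLD-1 cells (Homo sapiens) for antiproliferative activity, read by CellTiter-Glo, with a stated time of 72 h (on this read-out lower numbers stand for stronger inhibition and higher numbers for weaker inhibition), compound 1 `COc1ccccc1-c1ccc(S(=O)(=O)N2CCC(N3CCC(C)CC3)CC2)cc1` gives 26 nM, compound 2 `CC1CCN(C2CCN(S(=O)(=O)c3ccc(-c4ccccc4F)cc3)CC2)CC1` gives 5 nM and compound 3 `CC1CCN(C2CCN(S(=O)(=O)c3ccc(OC(F)(F)F)cc3)CC2)CC1` gives 16 nM. Compound 3 thus lies within the scatter of compound 1 and beyond the scatter of compound 2.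

The next structure is compound 4 `CC1CCN(C2CCN(S(=O)(=O)c3ccc(C(C)(C)C)cc3)CC2)CC1`, with tert-butyl in place of trifluoromethoxy on an aromatic carbon, para to a large group: tert-butyl in place of trifluoromethoxy on an aromatic carbon.

Two measured steps involve trifluoromethoxy at this place. One is a 1.6-fold lower number from compound 1 to compound 3 (0.21 log units; within the scatter), which stays within the scatter, and the other is a 3.2-fold higher number from compound 2 to compound 3 (0.51 log units; beyond the scatter), which is modest. A third, a 5.2-fold lower number from compound 1 to compound 2 (0.72 log units; beyond the scatter), is also modest and comes with fluoro in place of methoxy. Among the compounds with values here, no measured compound carries tert-butyl, so none of these steps tests that group directly. With only modest steps or smaller seen so far, the expectation in this assay is no step beyond the scatter, though a modest move either way remains possible. The expected step is a 1.3-fold higher number from compound 3 to compound 4 (0.10 log units; within the scatter). For compound 4 the estimated value is 20 nM, with an expected range of 7 nM to 60 nM.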

Compound 4, half-maximal inhibitory concentration: > 5000 nM
Compound 4 gave a limit, no number; the forecaster's own chance of this, stated with the estimate: 2%; at least 250-fold (2.39 log units) between middle value and limit.
By their numbers in this assay, from the lowest: compound 2; then compounds 3 and 1 (each within the scatter of the next). At a limit, above all of these: compound 4.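

In this assay compound 4 gives a limit and not a number: the limit of > 5000 nM in this assay, at which 1 of the 4 values shown sits. Tert-butyl in place of the earlier groups, on an aromatic carbon para to a large group, brings steps far larger than any seen among compounds 1 to 3: an at least 310-fold higher number from compound 3 to compound 4 (2.49 log units; beyond the scatter) against trifluoromethoxy, an at least 1000-fold higher number from compound 2 to compound 4 (3.00 log units; beyond the scatter) against 2-fluorophenyl and an at least 190-fold higher number from compound 1 to compound 4 (2.28 log units; beyond the scatter) against 2-methoxyphenyl. This place therefore does not accept every group: trifluoromethoxy and tert-butyl both have no ring and no net charge, yet only the first keeps a measurable value, and the plainest computed difference is the hydrogen-bond acceptor that tert-butyl lacks, though nothing here shows that this is the cause.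

On these data alone, whether the loss is particular to tert-butyl stays open, and an isopropyl group, a methoxy group or an amine at this place would help to separate the branched carbon from the missing oxygen. The compounds shown also leave open whether the loss arises at the target or in the cells.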